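Bromo-to-Iodo Exchange on a Thiophene Ring, Vero Cytotoxicity

The compounds below may be only part of what the source reports. "The series", "measured", "known", "first", "only" and "open" are said of these compounds alone.

Measured compounds:
Compound 1 `O=C(/C=C/c1ccc(N2CCCCC2)cc1)c1ccc(Br)s1`: 69500 nM
Compound 2 `O=C(/C=C/c1ccc(N2CCCCC2)cc1)c1ccc(I)s1`: 56500 nM
Compound 3 `Brc1ccc(C2=NNC(c3ccc(N4CCCCC4)cc3)C2)s1`: 25800 nM

Of the compounds shown here, three have been measured in an ADME assay on Vero cells (Chlorocebus sabaeus) for cytotoxicity, with a stated time of 5 days; a lower number here means a stronger inhibitor, a higher number a weaker inhibitor. Compound 1 gives 69500 nM and compound 2 gives 56500 nM; the two differ by iodo in place of bromo on an aromatic carbon, and the step of a 1.2-fold lower number from compound 1 to compound 2 (0.09 log units; within the scatter) is small. Compound 3 gives 25800 nM, the lowest of the three numbers; the difference between its core and the core of compound 1 is not broken down here.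

Compound 4 `Ic1ccc(C2=NNC(c3ccc(N4CCCCC4)cc3)C2)s1` is not yet measured in this assay. It differs from compound 3 by iodo in place of bromo on an aromatic carbon, the same change that separates compound 1 from compound 2, with the same surroundings at the place of exchange.

Because the step of a 1.2-fold lower number from compound 1 to compound 2 (0.09 log units; within the scatter) stayed within the scatter, the step from compound 3 to compound 4 is expected to be of the same modest size, a 1.2-fold lower number from compound 3 to compound 4 (0.07 log units; within the scatter). For compound 4 the estimated value in this assay is 22000 nM, with an expected range from 11000 nM to 45000 nM.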

Compound 4, half-maximal inhibitory concentration: 15900 nM
Compound 4: the middle estimate sits 1.4-fold (0.14 log units) above what was measured; the measured number falls inside the stated range.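

In this assay, the exchange of 5-bromothiophen-2-yl for 5-iodothiophen-2-yl gives a 1.6-fold lower number from compound 3 to compound 4 (0.21 log units; within the scatter), so on this core too the step cannot be told apart from repeat measurement. Set beside the earlier case, the two steps agree: the same change on two cores in this assay, a 1.2-fold lower number (0.09 log units; within the scatter) from compound 1 to compound 2 and a 1.6-fold lower number (0.21 log units; within the scatter) from compound 3 to compound 4, 1.3-fold (0.12 log units) apart, within the scatter of two such steps. This shows that, on these two cores and in this one assay, the exchange carries over as a small step, but with both steps within the scatter it fixes no firm direction for iodo against bromo, and two cores say nothing about whether the step would stay small on a third.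

The compounds shown leave open whether a different group on the same aromatic carbon, such as chloro, a nitrile or an amine, would sit as close to bromo and iodo as these two sit to each other. They also leave open whether the exchange holds on any core other than those of compound 1 and compound 3.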